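Halogen pattern on the aryl ring and Vero tolerance

The source may hold more compounds than are shown below. What is called first, only, known or untested is meant among the compounds shown, and "the series" means these compounds.

Three compounds share the core of compound 1 `C[C@]1(CN2CCc3nc(-c4ccc(OC(F)(F)F)cc4)ccc3C2)Cn2cc([N+](=O)[O-])nc2O1` and differ only in the aryl group. For compound 1 the entry in an ADME assay on Vero cells (Chlorocebus sabaeus) for cytotoxicity, read by MTT assay, with a stated time of 72 h (a higher number here means that more compound is tolerated, a lower number that less compound is tolerated), reads "not determined" (no result reported). Compound 2 `C[C@]1(CN2CCc3nc(-c4ccc(F)cc4F)ccc3C2)Cn2cc([N+](=O)[O-])nc2O1` gives 12.5 ug/mL in this assay. Compound 3 `C[C@]1(CN2CCc3nc(-c4cccc(F)c4F)ccc3C2)Cn2cc([N+](=O)[O-])nc2O1` is reported in this assay only as a limit of the assay, > 32 ug/mL, and not as a number. For the measured compounds named here, compound 3 therefore stands at the tolerated end of the values shown: the step of an at least 2.5-fold higher number from compound 2 to compound 3 (0.40 log units; beyond the scatter) is the only measured step, and it ends at the limit of > 32 ug/mL in this assay, at which 1 of the 3 values shown sits.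

Compound 4 `C[C@]1(CN2CCc3nc(-c4ccc(Cl)cc4F)ccc3C2)Cn2cc([N+](=O)[O-])nc2O1` carries the change (4-chloro-2-fluorophenyl in place of 2,3-difluorophenyl on an aromatic carbon), placed on an aromatic carbon of a six-membered aromatic ring with one nitrogen, part of a fused system of two rings. Going by the values given here, the only step that bears on this change is the one from compound 2 to compound 3, where moving the second halogen across the ring changed the number by at least a modest amount. Compound 4 returns to the substitution pattern of compound 2, with chlorine in place of one fluorine, so a step back toward the value of compound 2 is expected, an at least 2.0-fold lower number from compound 3 to compound 4 (0.30 log units; that floor lies within the scatter), though the limit at compound 3 leaves its size open. Compound 4 is estimated at 16 ug/mL in this assay, within 6 ug/mL to 40 ug/mL.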

Compound 4, half-maximal cytotoxic concentration: > 32 ug/mL
Compound 4 was reported as a limit; the forecaster's own chance of this, stated with the estimate: 35%; middle value at least 2.0-fold (0.30 log units) from the limit.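

In this assay, chloro in place of fluoro on an aromatic carbon gives an at least 2.5-fold higher number from compound 2 to compound 4 (0.40 log units; beyond the scatter), so the lower number of compound 2 does not extend to every aryl group that keeps a halogen at the same two ring carbons. For the compounds shown here, this position, on the ring carbon next to the ring nitrogen, therefore accepts 4-chloro-2-fluorophenyl as well as 2,3-difluorophenyl without a number below the limit of the assay, and only 2,4-difluorophenyl gives a measured value so far. The step between compound 3 and compound 4 cannot be read, as both entries are limits and not numbers, and the series now reads as two distinct aryl groups sharing the top of the range: the limit of > 32 ug/mL in this assay, at which 2 of the 4 values shown sit.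

As far as these compounds go, how far compound 3 and compound 4 lie past that limit stays open, and compound 1 adds no number with which to compare its aryl group. Also open, from the compounds shown here alone, is how this assay would read for an aryl group carrying a nitrile, an amine or a carboxylic acid in place of the halogens on the shared core.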